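This account rests on a few compounds, and the source may have more. Where it says the series, first, only, none or still open, it means among the compounds named here.

Measured so far in a functional assay (Cavia porcellus) with sulfonylurea receptors; K-ATP channels (Homo sapiens) as the target; on this read-out lower numbers stand for stronger inhibition and higher numbers for weaker inhibition:
compound 1 `CC(O)(C(=O)Nc1ccc(S(=O)(=O)c2ccccc2O)cc1)C(F)(F)F`, 3090 nM
compound 2 `CC(O)(C(=O)Nc1ccc(S(=O)(=O)c2ccccc2Cl)cc1)C(F)(F)F`, 2300 nM
compound 3 `CC(O)(C(=O)Nc1ccc(S(=O)(=O)c2cccc(Cl)c2)cc1)C(F)(F)F`, 10000 nM

Compound 3 stands at the highest of the three numbers. Its nearest neighbour is compound 1, reached by a 3.2-fold higher number from compound 1 to compound 3 (0.51 log units; beyond the scatter); the larger gap is to compound 2, a 4.3-fold higher number from compound 2 to compound 3 (0.64 log units; beyond the scatter). Between compound 1 and compound 2 the step is a 1.3-fold lower number from compound 1 to compound 2 (0.13 log units; within the scatter), so the two ring substituents found there give numbers that cannot be told apart.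

Compound 4 `CC(O)(C(=O)Nc1ccc(S(=O)(=O)c2cncnc2)cc1)C(F)(F)F` is not yet measured. It differs from compound 3 in one place: pyrimidin-5-yl in place of 3-chlorophenyl on a sulfonyl sulfur. Among the compounds with values here, no measured step swaps a carbon-only aromatic ring for one with hetero atoms, so nothing here bears on this exchange directly. Within the data shown here, the only relevant information is that compound 3 itself sits at the high end, and that the measured aryl variations moved the read-out by modest amounts. On that basis no large step in either direction is expected in this assay; the most likely outcome is a number near that of compound 3 or somewhat higher, as the step of a 1.5-fold higher number from compound 3 to compound 4 (0.18 log units; within the scatter) is meant to express. For compound 4 an estimate of 15000 nM is made, with a range of 4000 nM to 50000 nM, and a real chance that only a limit is returned.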

Compound 4, half-maximal inhibitory concentration: > 30000 nM
Compound 4 gave a limit, no number; the forecaster's own chance of this, stated with the estimate: 30%; at least 2.0-fold (0.30 log units) between middle value and limit.
By their numbers in this assay, from the lowest: compounds 2 and 1 (each within the scatter of the next); then compound 3. At a limit, above all of these: compound 4.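

In this assay compound 4, with pyrimidin-5-yl on the sulfonyl sulfur, returns a limit and not a number: the limit of > 30000 nM in this assay, at which 1 of the 4 values shown sits.

This is the only ring with hetero atoms on the sulfonyl sulfur among the compounds shown, and the exchange for 3-chlorophenyl gives an at least 3.0-fold higher number from compound 3 to compound 4 (0.47 log units; beyond the scatter), so a ring change at this place reaches beyond the range of the carbon-only aryl rings. Measured against the two groups carrying a substituent on the 2-position of the phenyl ring, the exchange gives an at least 13-fold higher number from compound 2 to compound 4 (1.11 log units; beyond the scatter) and an at least 9.7-fold higher number from compound 1 to compound 4 (0.98 log units; beyond the scatter), which shows that this place can carry much larger steps than the earlier aryl variations did, with the true size left unfixed by the limit.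

Whether the step follows the ring nitrogens or the absence of chlorine cannot be told from these compounds, since the exchange changes both at once. An unsubstituted phenyl or a pyridin-3-yl ring on the sulfonyl sulfur would separate the two, and a chloropyrimidine would test whether chlorine restores a measurable number in a ring with hetero atoms.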